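The source may hold more compounds than are shown below. What is called first, only, known or untested is meant among the compounds shown, and "the series" means these compounds.

Of the compounds shown here, three from this series have been tested in a functional assay on MCF7 cells (Homo sapiens) for cytotoxicity, read by MTT assay, with a stated time of 72 h; a higher number here means that more compound is needed for the effect, a lower number that less compound is needed. Compound 1 `COc1ccc(/C=C2\C(=O)N(c3c(Cl)cccc3Cl)c3ccccc32)cc1OC` gives 10 ug/mL. Compound 3 `O=C1/C(=C\c2ccc(O)cc2)c2ccccc2N1c1c(Cl)cccc1Cl` gives 20 ug/mL, and this number and that of compound 1 lie within the usual scatter of each other. Compound 2 `O=C1/C(=C\c2c(Cl)cccc2Cl)c2ccccc2N1c1c(Cl)cccc1Cl` returns only a limit, > 100 ug/mL, so no number is known for it. Among the compounds with values here, the one step that connects two measured compounds is an at least 5.0-fold lower number from compound 2 to compound 3 (0.69 log units; beyond the scatter), which rests on (the limit of > 100 ug/mL in this assay, at which 1 of the 3 values shown sits).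

Compound 4 `O=C1/C(=C\c2ccc(F)cc2)c2ccccc2N1c1c(Cl)cccc1Cl` differs from compound 3 in one place: fluoro in place of hydroxy on an aromatic carbon. Within the data shown here, no measured pair shows this swap; the only measured step replaced a 2,6-dichlorophenyl with a 4-hydroxyphenyl, which is a different change and can be used only as a rough guide that the group on the double-bonded chain carbon matters. A step expected for compound 4 is therefore small and uncertain, most likely towards a somewhat higher number or none beyond the scatter, giving a 1.5-fold higher number from compound 3 to compound 4 (0.18 log units; within the scatter). The expected value for compound 4 in this assay is 30 ug/mL, estimated to fall between 10 ug/mL and 100 ug/mL.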

Compound 4, concentration for half-maximal effect: 9 ug/mL
Estimate against measurement, compound 4: 3.3-fold (0.52 log units) above; measured number outside the range, below it.
By their numbers in this assay, from the lowest: compounds 4, 1 and 3 (each within the scatter of the next, the first and the last beyond it). At a limit, above all of these: compound 2.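

Within the data shown here, until now the only measured step at this part of the molecule replaced a whole ring, so nothing showed what a single group on that ring does. In this assay, the swap of hydroxy for fluoro on an aromatic carbon, para to a large group, gives a 2.2-fold lower number from compound 3 to compound 4 (0.35 log units; beyond the scatter), so the effect in these cells does not depend on keeping the hydroxy group, with its hydrogen-bond donor, at this place; the fluoro group, which has no such donor, gives a modest step in the favourable direction. A second ring swap, 4-fluorophenyl in place of 2,6-dichlorophenyl, gives an at least 11-fold lower number from compound 2 to compound 4 (1.04 log units; beyond the scatter), and the size of this step is only a bound, since the value of compound 2 is a limit and not a number: the limit of > 100 ug/mL in this assay, at which 1 of the 4 values shown sits.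

These compounds do not say why fluoro gives the lower number here, or whether the trend would extend to other groups at this place, such as an amine, a nitrile or a carboxylic acid. Among these compounds, with only one swap at this place, and with the other 2,6-dichlorophenyl group kept throughout, it also remains open how much that group adds to the effect.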